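Swapping the urea of compound 2 for an aryl carbamate

A few compounds are considered here, and "the series" means these few. Any claim that something is new, unique, unknown or untested is made for them only; others in the source may bear on it.

Of the compounds shown here, three have been measured in a functional assay on Shh Light II cells (Mus musculus) for inhibition, read by a luciferase reporter; a higher number here means a weaker inhibitor, a lower number a stronger inhibitor. Compound 1 `C[C@@H]1C[C@H](c2nc(-c3ccc4ccccc4n3)no2)CCN1C(=O)Nc1ccccc1Cl` gives 2400 nM, compound 2 `O=C(NCC1CCC1)N1CCC(c2nc(-c3ccc4ccccc4n3)no2)CC1` gives 410 nM, and compound 3 `COc1ccccc1NC(=O)N1CCC(c2noc(-c3ccc4ccccc4n3)n2)CC1` gives 2400 nM. On these numbers compound 2 stands lowest, and its gaps to compound 1 and to compound 3 both lie beyond the usual scatter of this assay, so compound 2 is the strongest inhibitor of the three.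

Compound 4 `COc1ccccc1OC(=O)N1CCC(c2nc(-c3ccc4ccccc4n3)no2)CC1` has not been measured. It differs from compound 2 in one place: 2-methoxyphenoxy in place of (cyclobutylmethyl)amino on a carbonyl carbon. Thus an aryl ether takes the place of an alkylamine on the carbonyl carbon whose other neighbour is the amide-type nitrogen in the ring.

No direct comparison between a pair of measured compounds isolates this kind of change. Still, the two compounds that carry an aromatic ring on this carbonyl, compound 1 with 2400 nM and compound 3 with 2400 nM, both sit well above compound 2, though each also differs from compound 2 elsewhere. The step from compound 2 to compound 4 is therefore expected to go upward in this assay, by about a 4.9-fold higher number from compound 2 to compound 4 (0.69 log units; beyond the scatter), a weakening beyond the scatter. Compound 4 is estimated to give about 2000 nM, most likely between 600 nM and 8000 nM.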

Compound 4, half-maximal inhibitory concentration: 250 nM
Compound 4: the middle estimate sits 8.0-fold (0.90 log units) above what was measured, outside the stated range (below it).
By their numbers in this assay, from the lowest: compounds 4 and 2 (each within the scatter of the next); then compounds 1 and 3 (each within the scatter of the next).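

In this assay, placing 2-methoxyphenoxy instead of (cyclobutylmethyl)amino on the carbonyl carbon gives a 1.6-fold lower number from compound 2 to compound 4 (0.21 log units; within the scatter), so this assay does not separate the two groups. Among these compounds, this is the first comparison that isolates a change at this position, and it shows that a group with a six-membered aromatic ring and no hydrogen-bond donor can stand on this carbonyl carbon with a result that matches the one for the alkylamine. The hydrogen-bond donor of (cyclobutylmethyl)amino is therefore not needed here for a number of this size, although nothing available explains why the exchange leaves the reading within the scatter.

The compounds shown leave open how much of this result belongs to the linking oxygen and how much to the ring, a question that cyclobutylmethoxy or 2-methoxyanilino on the same carbonyl and the same core would address. They also leave open what the methoxy group contributes, which plain phenoxy or 2-chlorophenoxy at this place would test.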